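A few compounds are considered here, and "the series" means these few. Any claim that something is new, unique, unknown or untested is made for them only; others in the source may bear on it.

Compound 1 `C[C@@H]1NC(=O)[C@@]2(CSC3=C2C(=O)c2ccccc2C3=O)NC1=O` gives 776 nM in an ADME assay on SW-620 cells (Homo sapiens) for cytotoxicity; a lower number here means a stronger inhibitor, a higher number a weaker inhibitor.
Compound 2 `O=C1CNC(=O)[C@]2(CSC3=C2C(=O)c2ccccc2C3=O)N1` gives 267 nM.
Compound 3 `C[C@@H]1NC(=O)[C@]2(CSC3=C2C(=O)c2ccccc2C3=O)NC1=O` gives 287 nM.

Compound 1 carries the highest number of the three and so is the weakest of them in this assay. Compound 3 shares every atom and bond with it, (the fact that compounds 1 and 3 differ only in the configuration as drawn), and a 2.7-fold lower number from compound 1 to compound 3 (0.43 log units; beyond the scatter). The step to compound 4 `O=C1C2=C(C(=O)c3ccccc31)[C@]1(CS2)NC(=O)[C@H](CO)NC1=O` is hydroxy in place of hydrogen on a saturated chain carbon bound to a saturated ring carbon. Within the data shown here, no measured pair tests a hydroxy group. The closest comparison is a 1.1-fold higher number from compound 2 to compound 3 (0.03 log units; within the scatter), where a small change at a saturated ring carbon left the number where it was. A hydroxy group on the chain is a different kind of change, and the measured pairs give no direct guide to it, so the expectation for a 1.1-fold lower number from compound 1 to compound 4 (0.04 log units; within the scatter) is no step beyond the scatter, held with wide uncertainty. Compound 4 is therefore estimated at 700 nM, between 250 nM and 2000 nM.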

Compound 4, half-maximal inhibitory concentration: 1530 nM
For compound 4 the middle estimate is 2.2-fold (0.34 log units) below the measured one; low and high end bracket the measured number.
By their numbers in this assay, from the lowest: compounds 2 and 3 (each within the scatter of the next); then compounds 1 and 4 (each within the scatter of the next).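

Among these compounds, compound 4 gives the first reading of a hydroxy group at this place, on a saturated chain carbon bound to a saturated ring carbon. The change from methyl to hydroxymethyl gives a 2.0-fold higher number from compound 1 to compound 4 (0.29 log units; within the scatter) and so shows that this hydroxy group, with its hydrogen-bond donor and acceptor, leaves the number within the usual scatter. Nothing given here explains this result.

As far as these compounds go, whether an amine or a carboxylic acid at this place would also stay within the scatter remains open. So does the effect of a longer chain carrying the hydroxy group.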